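The compounds below may be only part of what the source reports. "The series", "measured", "known", "first", "only" and "open" are said of these compounds alone.

Compound 1 `FC(F)(F)c1cccc(NC(=S)Nc2ccc(I)cc2)c1`: 9400 nM
Compound 2 `FC(F)(F)c1cccc(NC(=S)Nc2ccc(Cl)cc2)c1`: 10000 nM
Compound 3 `FC(F)(F)c1cccc(NC(=S)Nc2cccc(Br)c2)c1`: 10000 nM

All three values come from an ADME assay on BHK cells (Mesocricetus auratus) for cytotoxicity, read by MTT assay, with a stated time of 96 h (a higher number here means that more compound is tolerated, a lower number that less compound is tolerated), and they lie within the scatter of one another. Compound 3, at 10000 nM, stands level with compound 2, and compound 1 does not separate from either of them.

The next compound to be tested is compound 4 `Fc1ccccc1NC(=S)Nc1cccc(C(F)(F)F)c1`. It differs from compound 3 in one place: 2-fluorophenyl in place of 3-bromophenyl on an amide-type nitrogen.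

The three measured steps all concern the group at that same place. They run a 1.1-fold higher number from compound 1 to compound 2 (0.03 log units; within the scatter), then a 1.1-fold higher number from compound 1 to compound 3 (0.03 log units; within the scatter), and finally no change at the digits printed from compound 2 to compound 3 (within the scatter). Among these three compounds, then, exchanging 4-iodophenyl, 4-chlorophenyl and 3-bromophenyl has produced no step beyond the scatter in this assay. Within the data shown here, no measured compound carries the 2-fluorophenyl group, however, so this change goes beyond what the three compounds cover directly.

On that evidence, no step beyond the scatter is expected, and no direction is favoured. The expected step is a 1.2-fold higher number from compound 3 to compound 4 (0.08 log units; within the scatter). For compound 4 the estimate is 12000 nM, with an expected range from 5000 nM to 40000 nM.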

Compound 4, half-maximal cytotoxic concentration: 54000 nM
Beside the measured number, compound 4's estimate is 4.5-fold (0.65 log units) below it, outside the stated range (above it).
By their numbers in this assay, from the lowest: compounds 1, 2 and 3 (each within the scatter of the next); then compound 4.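

In this assay, the group on the amide-type nitrogen proves able to move the number: the 2-fluorophenyl group gives a 5.4-fold higher number from compound 3 to compound 4 (0.73 log units; beyond the scatter) and a 5.4-fold higher number from compound 2 to compound 4 (0.73 log units; beyond the scatter) and a 5.7-fold higher number from compound 1 to compound 4 (0.76 log units; beyond the scatter) while exchanges among the 4-iodophenyl, 4-chlorophenyl and 3-bromophenyl groups had produced no step beyond the scatter. This position is therefore not indifferent to its substituted phenyl group, and compound 4 stands apart from the other three with more compound tolerated, even though the entering and leaving groups hold equally many heavy atoms and differ only in their halogen and where it sits on the ring. Nothing available bears on why this step occurs.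

Compound 4 changes the halogen and its ring position together, so the compounds shown cannot say which of the two carries the step; the 3-fluorophenyl, 4-fluorophenyl and 2-chlorophenyl groups would separate them. They also leave open whether a halogen is needed at all, as neither an unsubstituted phenyl nor a 2-methoxyphenyl group on the same nitrogen is among them.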